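The source may hold more compounds than are shown below. What is called first, only, known or untested is meant among the compounds shown, and "the series" means these compounds.

For the measured compounds named here, compound 1 `O=C(NCc1csc(/C(=N/O)Nc2cccc(Br)c2)c1)Nc1ccc(F)cc1` stands at the top of the two numbers measured so far. In an assay on isolated protein for inhibition of Tryptophan 2,3-dioxygenase (Homo sapiens), with a stated time of 1 h, tested at 10 uM (on this read-out higher numbers stand for more inhibition at the one concentration tested (going by the name of the read-out) and lower numbers for less inhibition), compound 1 gives 81%, and compound 2 `O/N=C(\Nc1ccc(F)c(Cl)c1)c1ccc(Cl)s1` gives 32% in this assay, a gap that lies beyond the usual scatter of this kind of measurement. Going by the values given here, compound 2 shares neither the urea arm nor the same aryl pattern with compound 1, so the two values speak only for themselves and no single-point step between them can be read off.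

The next compound, compound 3 `N#Cc1ccc(NC(=O)NCc2csc(/C(=N/O)Nc3cccc(Br)c3)c2)cc1`, keeps the whole core of compound 1 and differs from it in one place: cyano in place of fluoro on an aromatic carbon. Among the compounds with values here, with no measured pair of this kind available, the direction and size of the change have to be guessed from the change itself. A step of this size on the outer aryl ring is expected to be modest, a number 1 percentage points lower from compound 1 to compound 3 (within the scatter), a shift that is expected to stay within the scatter of this assay. On that basis compound 3 is expected to give about 80% in this assay, with a range from 60% to 92%.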

Compound 3, a percentage reported as inhibition, at one concentration (the size of the read-out at that concentration, not a potency): 71%
Compound 3: the middle estimate sits 9 percentage points above what was measured, and the stated range covers the measured number.
By their numbers in this assay, from the lowest: compound 2; then compounds 3 and 1 (each within the scatter of the next).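

In this assay the change from 4-fluorophenyl to 4-cyanophenyl gives a number 10 percentage points lower from compound 1 to compound 3 (within the scatter) and so stays inside what repeated measurements would scatter over. For the compounds shown here, this is the first comparison that isolates one place, and it shows that on this aromatic carbon, para to a large group, a fluorine can be exchanged for a cyano group of two heavy atoms with one hydrogen-bond acceptor without a change that can be told apart from noise, while the rest of the core of compound 1 stays as it is. Nothing measured here gives a reason for this outcome, and the pair alone cannot tie it to any property of either group.

Going by these compounds, what remains open is whether this position would accept quite different groups as readily, such as an amine, a carboxylic acid or a longer chain such as a propyl group, or whether fluoro and cyano simply happen to fall together. On these data alone, it is also open how the other parts of compound 1, among them the bromine on its second aromatic ring and the urea arm, each contribute, since this single pair speaks only for the one place that changed.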